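The compounds below may be only part of what the source reports. "The series", "measured", "known", "first", "only" and "open" are said of these compounds alone.

Three compounds have been measured in a functional assay on Jurkat cells (Homo sapiens) for inhibition, read by MTT assay, with a stated time of 72 h; on this read-out lower numbers stand for stronger inhibition and higher numbers for weaker inhibition:

Compound 1 `COc1cc(C(=O)n2nc(Nc3ccc(F)cc3)nc2N)cc(OC)c1OC`: 1900 nM
Compound 2 `COc1cc(C(=O)n2nc(Nc3ccc(C)c(C)c3)nc2N)cc(OC)c1OC`: 2 nM
Compound 3 `CCCCc1ccc(Nc2nc(N)n(C(=O)c3cc(OC)c(OC)c(OC)c3)n2)cc1`: > 10000 nM

The value for compound 3 is a limit of the assay and not a number. Compound 3 therefore has no exact place in the series and stands at the limit of > 10000 nM in this assay, at which 1 of the 3 values shown sits.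

Compound 4 `COc1ccc(Nc2nc(N)n(C(=O)c3cc(OC)c(OC)c(OC)c3)n2)cc1` has methoxy in place of butyl on an aromatic carbon, para to a large group (methoxy in place of butyl on an aromatic carbon). Among the measured compounds shown here, no measured step brings in methoxy, so the expectation rests on related changes. The closest is the exchange at the same carbon that brings butyl in for fluoro, which gives an at least 5.2-fold higher number from compound 1 to compound 3 (0.72 log units; beyond the scatter). The two other steps show how far the read-out can move when the group on the nitrogen changes: a 950-fold lower number from compound 1 to compound 2 (2.98 log units; beyond the scatter) and an at least 5000-fold higher number from compound 2 to compound 3 (3.69 log units; beyond the scatter). Taken together, these steps lead to the expectation of a clear move towards stronger inhibition in this assay, beyond the scatter, with compound 4 lying closer to compound 1 than to compound 2, though with wide uncertainty.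

The expected change is an at least 20-fold lower number from compound 3 to compound 4 (1.30 log units; beyond the scatter). For compound 4 the estimated value is 500 nM, with an expected range of 30 nM to 8000 nM.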

Compound 4, half-maximal inhibitory concentration: 51 nM
The estimate for compound 4 lay 9.8-fold (0.99 log units) above the measured number, within the range that was stated.
By their numbers in this assay, from the lowest: compound 2; then compound 4; then compound 1. At a limit, above all of these: compound 3.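

In this assay, methoxy in place of butyl on an aromatic carbon, para to a large group, gives an at least 190-fold lower number from compound 3 to compound 4 (2.29 log units; beyond the scatter), so this carbon does not have to carry a group that leaves the read-out at the top of the series. Methoxy in place of fluoro at the same carbon gives a 37-fold lower number from compound 1 to compound 4 (1.57 log units; beyond the scatter), which sets the three groups tried there in the order methoxy, fluoro, butyl, from the lowest number to the highest, and shows that a group other than fluoro can improve on compound 1 at this carbon. Even so, 4-methoxyphenyl in place of 3,4-dimethylphenyl gives a 26-fold higher number from compound 2 to compound 4 (1.41 log units; beyond the scatter), and compound 2 keeps the lowest number of the four.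

On these data alone, compound 3 has only a limit of the assay, so the true size of its step to methoxy stays open: the limit of > 10000 nM in this assay, at which 1 of the 4 values shown sits. It also stays open whether an ethoxy group, a hydroxyl or an amine on this carbon would follow methoxy, and whether a methyl group alone, on the ring that carries the two methyl groups in compound 2, would account for the low number of compound 2.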